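Swapping a Hydroxyphenyl for Thiophene in a Thiosemicarbazone

The compounds below may be only part of what the source reports. "The series", "measured", "known", "first", "only" and "open" are said of these compounds alone.

Going by the values given here, compound 1 `CC1=CC[C@H](C(C)(C)NC(=S)N/N=C/c2ccccc2O)CC1` is the only member of this small set with an actual number: in a functional assay on NCI/ADR-RES cells (Homo sapiens) for inhibition, read by sulforhodamine B assay, with a stated time of 48 h (a higher number here means a weaker inhibitor of growth, a lower number a stronger inhibitor of growth), compound 1 gives 10900 nM. Compound 2 `CC1=CC[C@H](C(C)(C)NC(=S)N/N=C/c2ccc(N(C)C)cc2)CC1` reaches only the assay limit, > 100000 nM. Compound 3 `CC1=CC[C@H](C(C)(C)NC(=S)N/N=C/c2ccccc2[N+](=O)[O-])CC1` likewise stops at the limit, > 100000 nM. These two values sit at the limit of > 100000 nM in this assay, at which 2 of the 3 values shown sit. Among the compounds with values here, the one measured step, an at least 9.1-fold higher number from compound 1 to compound 3 (0.96 log units; beyond the scatter), removed the hydroxy and weakened growth inhibition at least modestly. Compound 4 `CC1=CC[C@H](C(C)(C)NC(=S)N/N=C/c2cccs2)CC1` differs from compound 1 by thiophen-2-yl in place of 2-hydroxyphenyl on a carbon with a double bond to nitrogen, which again removes the hydroxy. Given an at least 9.1-fold higher number from compound 1 to compound 3 (0.96 log units; beyond the scatter), compound 4 is expected to inhibit growth more weakly, a step of a 2.8-fold higher number from compound 1 to compound 4 (0.44 log units; beyond the scatter). The estimate for compound 4 is 30000 nM, between 8000 nM and 100000 nM.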

Compound 4, concentration for total growth inhibition: 41000 nM
Compound 4: the middle estimate sits 1.4-fold (0.14 log units) below what was measured; the range from low to high includes it.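

In this assay, thiophen-2-yl in place of 2-hydroxyphenyl gives a 3.8-fold higher number from compound 1 to compound 4 (0.58 log units; beyond the scatter) and so only a modest loss of growth inhibition. Unlike the earlier change that removed the hydroxy, this one has an exact size, and compound 4 keeps a real value with no hydrogen-bond donor in this group. That sets compound 4 apart from the two compounds that give no exact number: the limit of > 100000 nM in this assay, at which 2 of the 4 values shown sit.

The compounds shown do not separate the loss of the hydroxy from the change of ring. On these data alone, how a methoxy group or a carboxylic acid in place of the hydroxy would read also stays open.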